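The compounds below may be only part of what the source reports. "The series", "measured", "known", "first", "only" and "open" are said of these compounds alone.

Compound 1 `Sc1nnc(-c2ccc3c(c2)OCCO3)n1-c1ccccc1`: 38400 nM
Compound 2 `Brc1ccccc1CSc1nnc(-c2ccc3c(c2)OCCO3)n1-c1ccccc1`: 7350 nM

Both values were measured in a functional assay on SW 1116 cells (Homo sapiens) for antiproliferative activity, read by MTT assay, with a stated time of 24 h; on this read-out higher numbers stand for weaker inhibition and lower numbers for stronger inhibition. Compound 2 holds the lower of the two numbers at 7350 nM, so it is the stronger inhibitor of the pair. Within the data shown here, the one measured step is a 5.2-fold lower number from compound 1 to compound 2 (0.72 log units; beyond the scatter). It is a modest step beyond the scatter, seen with 2-bromobenzyl in place of hydrogen on the sulfur.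

Compound 3 `Brc1cccc(CSc2nnc(-c3ccc4c(c3)OCCO4)n2-c2ccccc2)c1` departs from compound 2 in one place: 3-bromophenyl in place of 2-bromophenyl on a saturated chain carbon bound to a sulfur. It carries 3-bromophenyl in place of 2-bromophenyl on a saturated chain carbon bound to a sulfur, so the 2-bromobenzyl becomes 3-bromobenzyl. Among the measured compounds shown here, no measured compound carries this group, so the data show no direction for the change. For the measured compounds named here, the only guide is compound 2 itself, with its step of a 5.2-fold lower number from compound 1 to compound 2 (0.72 log units; beyond the scatter), which concerns adding the whole group rather than rearranging it. A smaller step is therefore expected here, probably none beyond the scatter. The expected change is a 1.1-fold lower number from compound 2 to compound 3 (0.02 log units; within the scatter). For compound 3 the estimated value in this assay is 7000 nM, with an expected range from 2500 nM to 20000 nM.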

Compound 3, half-maximal inhibitory concentration: 26200 nM
Compound 3: the middle estimate sits 3.7-fold (0.57 log units) below what was measured, and the stated range ends below it.
By their numbers in this assay, from the lowest: compound 2; then compounds 3 and 1 (each within the scatter of the next).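

Compound 3 has the same atoms as compound 2, and the two groups exchanged have identical counts, yet changing 2-bromobenzyl to 3-bromobenzyl gives a 3.6-fold higher number from compound 2 to compound 3 (0.55 log units; beyond the scatter) in this assay, so at this place on the sulfur the arrangement of the group matters and not only its presence. The lower number of compound 2 therefore does not follow from placing just any bromobenzyl on the sulfur: with 3-bromobenzyl in place of hydrogen on the sulfur there is a 1.5-fold lower number from compound 1 to compound 3 (0.17 log units; within the scatter), which leaves compound 3 indistinguishable from compound 1 on this read-out. No measurement at hand accounts for this difference between the two bromobenzyl groups.

The compounds shown leave open whether the bromine contributes at all to the lower number of compound 2, since a plain benzyl group on the sulfur does not appear among them. They also leave open whether a chlorine or a methoxy group in place of the bromine of 2-bromobenzyl would keep that lower number, or whether it belongs to 2-bromobenzyl alone.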